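Trifluoromethyl added to a nitrile-bearing ring: an expected value

A few compounds are considered here, and "the series" means these few. Any claim that something is new, unique, unknown or untested is made for them only; others in the source may bear on it.

Measured so far:
compound 1, `CC(O)(CSc1cccc(C(F)(F)F)c1)C(=O)Nc1cccc(S(F)(F)(F)(F)F)c1`, 12700 nM
compound 2, `CC(O)(CSc1cc(C(F)(F)F)cc(C(F)(F)F)c1)C(=O)Nc1cccc(S(F)(F)(F)(F)F)c1`, 4800 nM
compound 3, `CC(O)(COc1ccc(C#N)cc1)C(=O)Nc1cccc(S(F)(F)(F)(F)F)c1`, 30000 nM

All three were tested in a functional assay on LNCaP cells (Homo sapiens) for antiproliferative activity, read by propidium iodide staining, with a stated time of 96 h; on this read-out higher numbers stand for weaker inhibition and lower numbers for stronger inhibition. Compound 1 gives 12700 nM, compound 2 gives 4800 nM and compound 3 gives 30000 nM. One change is seen twice here. In the measured pair it is trifluoromethyl in place of hydrogen on an aromatic carbon, and it produced a 2.6-fold lower number from compound 1 to compound 2 (0.42 log units; beyond the scatter). The difference between the core of compound 1 and the core of compound 3 is not broken down here.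

Compound 4, `CC(O)(COc1ccc(C#N)cc1C(F)(F)F)C(=O)Nc1cccc(S(F)(F)(F)(F)F)c1`, has not yet been measured. It differs from compound 3 by trifluoromethyl in place of hydrogen on an aromatic carbon. This is the same kind of change as the measured one, not the same: there the place was meta to a large group and meta to a trifluoromethyl group, here it is ortho to a large group and meta to a cyano group.

For compound 4 in this assay a step of about a 2.1-fold lower number from compound 3 to compound 4 (0.33 log units; beyond the scatter) is expected, resting on the measured step from compound 1 to compound 2, a 2.6-fold lower number from compound 1 to compound 2 (0.42 log units; beyond the scatter), weighed against the differing surroundings of the place. Compound 4 is therefore estimated at 14000 nM, between 6000 nM and 32000 nM.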

Compound 4, half-maximal inhibitory concentration: 16400 nM
Estimate against measurement, compound 4: 1.2-fold (0.07 log units) below; the measured number falls inside the stated range.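

In this assay, trifluoromethyl in place of hydrogen on the ring bearing the nitrile gives a 1.8-fold lower number from compound 3 to compound 4 (0.26 log units; within the scatter), so this step alone does not separate compound 3 from compound 4. What the two cores do show is limited: the new step is consistent with the earlier one, but it does not establish that the gain seen on the first core carries over, and two pairs of compounds make no general rule for this series. Set side by side, the two steps cannot be told apart: the same change on two cores in this assay, a 2.6-fold lower number (0.42 log units; beyond the scatter) from compound 1 to compound 2 and a 1.8-fold lower number (0.26 log units; within the scatter) from compound 3 to compound 4, 1.4-fold (0.16 log units) apart, within the scatter of two such steps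

From the compounds shown here alone, whether a smaller group at the same place, such as a methyl group or a chlorine atom, would give a similar step remains open. Also open, going by these compounds, is how far the step depends on the rest of the core, since compound 1 and compound 3 differ in more than one place and their cores cannot be compared directly.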